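The source may report more compounds than this note shows. Statements on the series, on what has been measured and on what is new or still open speak of the compounds shown alone.

Going by the values given here, in a functional assay on HCT-116 cells (Homo sapiens) for antiproliferative activity, read by CCK-8 assay, with a stated time of 72 h (on this read-out lower numbers stand for stronger inhibition and higher numbers for weaker inhibition), compound 1 (`Nc1ccccc1NC(=O)c1ccc(CSC(=S)N2CCN(c3ccccc3)CC2)cc1`) gives 2330 nM and compound 2 (`Nc1ccccc1NC(=O)c1ccc(CSC(=S)N2CCc3ccccc32)cc1`) gives 2700 nM as the only two numbers so far. These two values lie within the usual scatter of each other, so compound 1 cannot be ranked apart from compound 2. Compound 3 (`Nc1ccccc1NC(=O)c1ccc(CSC(=S)N2CCN(c3ccc(F)cc3)CC2)cc1`) differs from compound 1 at one place (fluoro in place of hydrogen on an aromatic carbon) with fluoro in place of hydrogen on an aromatic carbon, taking phenyl to 4-fluorophenyl. Among the compounds with values here, no pair of measured compounds differs in one place, so the data give no direct measure for this change. In this assay no step beyond the scatter is expected, and no direction can be supported. The expected size is a 1.2-fold lower number from compound 1 to compound 3 (0.07 log units; within the scatter) and this remains an estimate. Compound 3 is estimated at 2000 nM with an expected range from 800 nM to 5000 nM in this series.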

Compound 3, half-maximal inhibitory concentration: 2730 nM
Compound 3: the middle estimate sits 1.4-fold (0.14 log units) below what was measured, and the stated range covers the measured number.
By their numbers in this assay, from the lowest: compounds 1, 2 and 3 (each within the scatter of the next).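

In this assay, going by these compounds alone, placing fluoro on the aromatic carbon para to a large group gives a 1.2-fold higher number from compound 1 to compound 3 (0.07 log units; within the scatter) and provides the first reading of a one-place change. Within the data shown here, at this position, therefore, 4-fluorophenyl cannot be told apart from phenyl, and a single fluoro gives no measurable step in this read-out. No measurement at hand explains this result or links it to any property of the fluoro group.

From the compounds shown here alone, it remains open whether an amine, a carboxylic acid or a methoxy group at this same carbon would give a step beyond the scatter. Also open, going by these compounds, is how the number would respond to fluoro on another carbon of this ring, or to a longer chain in place of the phenyl on the core of compound 1.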